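Compound 3 to compound 4: butyl to 2-hydroxyethyl

The compounds below may be only part of what the source reports. "The series", "measured", "known", "first", "only" and "open" are said of these compounds alone.

In a functional assay on HeLa cells (Homo sapiens) for antiproliferative activity, read by sulforhodamine B assay (a lower number here means a stronger inhibitor of growth, a higher number a weaker inhibitor of growth), compound 1 (`c1ccc(COC[C@H]2OCC[C@@H](OCc3ccccc3)[C@@H]2OCc2ccccc2)cc1`) gives 33300 nM as a measured number. Compound 2 (`CCC[C@@H]1O[C@H](COCc2ccc3ccccc3c2)[C@@H](OCc2ccc3ccccc3c2)[C@H](OCc2ccc3ccccc3c2)[C@H]1O`) gives > 50000 nM as a limit only. Compound 3 (`CCCC[C@@H]1O[C@H](COCc2ccccc2)[C@@H](OCc2ccccc2)[C@H](OCc2ccccc2)[C@H]1O`) likewise gives > 50000 nM as a limit only. Compound 3 therefore stands at the limit of > 50000 nM in this assay, at which 2 of the 3 values shown sit, and has no exact starting number. Compound 4 (`OCC[C@@H]1O[C@H](COCc2ccccc2)[C@@H](OCc2ccccc2)[C@H](OCc2ccccc2)[C@H]1O`) has hydroxy in place of ethyl on a saturated chain carbon, two bonds along the chain from a saturated ring carbon. No measured step sizes this change, so only a small shift towards stronger growth inhibition is expected, possibly none beyond the scatter. The estimated step is an at least 1.2-fold lower number from compound 3 to compound 4 (0.09 log units; that floor lies within the scatter) in this assay and remains uncertain. Compound 4 is expected at 40000 nM with 15000 nM to 70000 nM as the estimated range.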

Compound 4, concentration for 50% growth inhibition: 30200 nM
Beside the measured number, compound 4's estimate is 1.3-fold (0.12 log units) above it; measured number inside the range.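

In this assay, exchanging butyl for 2-hydroxyethyl at this position gives compound 4 a measured number, where compound 3 gives only a limit. The change reads as an at least 1.6-fold lower number from compound 3 to compound 4 (0.21 log units; that floor lies within the scatter). This step is only a floor because compound 3 has no exact number: the limit of > 50000 nM in this assay, at which 2 of the 4 values shown sit.

As far as these compounds go, how far the true step lies past that floor stays open. Also open, from the compounds shown here alone, is whether an amine or a carboxylic acid at the end of this chain, or a longer chain carrying the hydroxy, would shift growth inhibition further.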